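Swapping a ring for a chain on compound 1

A few compounds are considered here, and "the series" means these few. Any claim that something is new, unique, unknown or untested is made for them only; others in the source may bear on it.

Compound 1 `Cc1cc(N2CCC[C@H](COCc3nc(C)no3)C2)c2c(N)c(C(N)=O)sc2n1` gives 451 nM
Compound 2 `NC(=O)c1sc2nccc(N3CCC[C@H](COCCO)C3)c2c1N` gives 326 nM

Both values come from an ADME assay on the whole organism (Rattus norvegicus, strain Fischer 344) for pharmacokinetics, at a dose of 3 mg/kg by the oral route (on this read-out higher numbers stand for higher exposure at the dose given and lower numbers for lower exposure), and they lie within the usual scatter of each other, so compound 1 and compound 2 cannot be told apart on these numbers.

Compound 3 `CCOCCOC[C@H]1CCCN(c2cc(C)nc3sc(C(N)=O)c(N)c23)C1` differs from compound 1 by a single change ethoxymethyl in place of 3-methyl-1,2,4-oxadiazol-5-yl on a saturated chain carbon bound to an oxygen on a saturated carbon and carries ethoxymethyl in place of 3-methyl-1,2,4-oxadiazol-5-yl on a saturated chain carbon bound to an oxygen on a saturated carbon. The same difference can be read as 2-ethoxyethoxy in place of (3-methyl-1,2,4-oxadiazol-5-yl)methoxy. For the measured compounds named here, no measured pair shows this change on its own, so this assay offers no direct guide to its size.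

With only compound 1 at 451 nM and compound 2 at 326 nM to go on, a large step is not expected. A slight downward move is expected, and the estimated change is a 1.5-fold lower number from compound 1 to compound 3 (0.18 log units; within the scatter) which would stay within the scatter. Compound 3 is estimated at 300 nM in this assay with 120 nM to 750 nM as the expected range of values.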

Compound 3, maximal plasma concentration: 909 nM
Estimate against measurement, compound 3: 3.0-fold (0.48 log units) below; measured number above the stated range.
By their numbers in this assay, from the lowest: compounds 2, 1 and 3 (each within the scatter of the next, the first and the last beyond it).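

For the compounds shown here, compound 1 and compound 3 form the first pair here that differs in one place, and in this assay the step, a 2.0-fold higher number from compound 1 to compound 3 (0.30 log units; within the scatter), lies within the usual scatter. On a saturated chain carbon bound to an oxygen on a saturated carbon, the five-membered aromatic ring of 3-methyl-1,2,4-oxadiazol-5-yl can therefore give way to ethoxymethyl, which has no ring, with no change that these numbers can separate from scatter, so the ring is not required at this place for exposure in this read-out. Nothing measured here explains this result or links it to any property of either group.

As far as these compounds go, it remains open whether the same place would accept a group of another kind, such as a primary amine, a carboxylic acid or a longer ether chain, and whether a ring other than the oxadiazole would read the same way. Also open, from the compounds shown here alone, is whether ethoxymethyl would give a similar result on the core of compound 2, and whether the other pharmacokinetic read-outs of compound 1 and compound 3 would fall as close together as their maximal concentrations do.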